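Series notes: replacing the piperazine arm of compound 1

The source may report more compounds than this note shows. Statements on the series, on what has been measured and on what is new or still open speak of the compounds shown alone.

Measured so far: compound 1 `NS(=O)(=O)c1cc(-c2nnc(CN3CCN(c4ccccc4)CC3)o2)c(Cl)cc1SCc1ccccc1`, 295000 nM; compound 2 `NS(=O)(=O)c1cc(-c2nnc(CN3CCN(c4ccc(F)cc4)CC3)o2)c(Cl)cc1SCc1ccccc1`, 240000 nM; compound 3 `Cc1ccc(C)c(N2CCN(Cc3nnc(-c4cc(S(N)(=O)=O)c(SCc5ccccc5)cc4Cl)o3)CC2)c1`, 51000 nM.

In a functional assay on MCF7 cells (Homo sapiens) for cytotoxicity, read by MTT assay, with a stated time of 72 h (on this read-out higher numbers stand for weaker inhibition and lower numbers for stronger inhibition), compound 1 gives the highest of the three numbers; compound 2 sits within the scatter of it, a 1.2-fold lower number from compound 1 to compound 2 (0.09 log units; within the scatter), while compound 3 lies further off, a 5.8-fold lower number from compound 1 to compound 3 (0.76 log units; beyond the scatter). Compound 4 `NC(=O)c1cn(Cc2nnc(-c3cc(S(N)(=O)=O)c(SCc4ccccc4)cc3Cl)o2)nn1` carries 4-carbamoyl-1H-1,2,3-triazol-1-yl in place of 4-phenylpiperazin-1-yl on a saturated chain carbon bound to an aromatic carbon. The measured steps, including a 4.7-fold lower number from compound 2 to compound 3 (0.67 log units; beyond the scatter), all keep the piperazine arm and vary only the group on its amine nitrogen, so none bears directly on removing that arm; the data give no guidance here. For compound 4 no step beyond the scatter is therefore expected, a 1.0-fold higher number from compound 1 to compound 4 (0.01 log units; within the scatter), and its value is estimated at 300000 nM, with a wide range from 90000 nM to 900000 nM.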

Compound 4, half-maximal inhibitory concentration: 78000 nM
For compound 4 the middle estimate is 3.8-fold (0.59 log units) above the measured one, and the stated range ends above it.
By their numbers in this assay, from the lowest: compounds 3 and 4 (each within the scatter of the next); then compounds 2 and 1 (each within the scatter of the next).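

At this position the whole 4-phenylpiperazin-1-yl arm can give way to 4-carbamoyl-1H-1,2,3-triazol-1-yl, with a 3.8-fold lower number from compound 1 to compound 4 (0.58 log units; beyond the scatter) in this assay. The piperazine ring and its phenyl group are therefore not needed for a reading at this level, so the change reaches further than the earlier variation on the amine nitrogen. Nothing at hand accounts for the step.

From the compounds shown here alone, whether the step follows the five-membered aromatic ring or the carbamoyl group stays open. A carboxylic acid or a nitrile in place of the carbamoyl group would help separate the two.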